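Naphthyl sulfonamide on a hydroxyphenyl core: expected cytotoxicity

The source may report more compounds than this note shows. Statements on the series, on what has been measured and on what is new or still open speak of the compounds shown alone.

Of the compounds shown here, three have been measured in a functional assay on LOX IMVI cells (Homo sapiens) for cytotoxicity, read by MTT assay, with a stated time of 24 h; on this read-out lower numbers stand for stronger inhibition and higher numbers for weaker inhibition. Compound 1 `COc1ccc(S(=O)(=O)NCCCNc2nccc(-c3[nH]c(-c4ccccc4)nc3-c3ccc(Cl)c(OC)c3)n2)cc1` gives 1800 nM. Compound 2 `COc1cc(-c2nc(-c3ccccc3)[nH]c2-c2ccnc(NCCCNS(=O)(=O)c3cccc4ccccc34)n2)ccc1Cl` gives 13500 nM, and compound 3 `COc1ccc(S(=O)(=O)NCCCNc2nccc(-c3[nH]c(-c4ccccc4)nc3-c3ccc(Cl)c(O)c3)n2)cc1` gives 36800 nM, the highest of the three numbers. The change naphthalen-1-yl in place of 4-methoxyphenyl on a sulfonyl sulfur produced a 7.5-fold higher number from compound 1 to compound 2 (0.88 log units; beyond the scatter). The cores of compound 1 and compound 3 differ by hydrogen in place of methyl on an oxygen on an aromatic ring, which produced a 20-fold higher number from compound 1 to compound 3 (1.31 log units; beyond the scatter). Compound 4 `O=S(=O)(NCCCNc1nccc(-c2[nH]c(-c3ccccc3)nc2-c2ccc(Cl)c(O)c2)n1)c1cccc2ccccc12` is not yet measured; it differs from compound 3 by naphthalen-1-yl in place of 4-methoxyphenyl on a sulfonyl sulfur, the same change seen from compound 1 to compound 2, at the same place. Compound 4 is expected to show a similar step, a 5.4-fold higher number from compound 3 to compound 4 (0.74 log units; beyond the scatter), because compound 1 to compound 2 gave a 7.5-fold higher number from compound 1 to compound 2 (0.88 log units; beyond the scatter). Compound 4 is therefore estimated at 200000 nM in this assay, with a range from 60000 nM to 600000 nM.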

Compound 4, half-maximal inhibitory concentration: 7720 nM
For compound 4 the middle estimate is 26-fold (1.41 log units) above the measured one, outside the stated range (below it).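

The change to naphthalen-1-yl on the sulfonyl sulfur gave a 4.8-fold lower number from compound 3 to compound 4 (0.68 log units; beyond the scatter), so it did not carry over between the two cores and instead ran in the opposite direction: the same change on two cores in this assay, a 7.5-fold higher number (0.88 log units; beyond the scatter) from compound 1 to compound 2 and a 4.8-fold lower number (0.68 log units; beyond the scatter) from compound 3 to compound 4, 36-fold (1.55 log units) apart, beyond the scatter of two such steps. Hydrogen in place of methyl on the oxygen did not carry over either, giving a 1.7-fold lower number from compound 2 to compound 4 (0.24 log units; within the scatter): the same change on two cores in this assay, a 20-fold higher number (1.31 log units; beyond the scatter) from compound 1 to compound 3 and a 1.7-fold lower number (0.24 log units; within the scatter) from compound 2 to compound 4, 36-fold (1.55 log units) apart, beyond the scatter of two such steps. These four compounds show that neither step can be transferred from one core to the other here, but they do not explain why, and they say nothing about other groups.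

As far as these compounds go, it remains open how a plain phenyl on the sulfonyl sulfur would behave on each core. Also open, from the compounds shown here alone, is whether an ethyl in place of methyl on the oxygen would show the same dependence on the sulfonyl group.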